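Methoxy for methyl on the shared core: what to expect

The compounds below may be only part of what the source reports. "The series", "measured", "known", "first", "only" and "open" are said of these compounds alone.

Three compounds built on one core have been compared in an assay on ileum (strain Hartley) with 5-hydroxytryptamine receptor 3A (Cavia porcellus) as the target; on this read-out lower numbers stand for smaller maximal responses and higher numbers for larger maximal responses. Compound 1 `CN1CCN(c2nc3cc([N+](=O)[O-])ccc3o2)CC1` gives 0.52, compound 2 `Cc1cc(C)c2oc(N3CCN(C)CC3)nc2c1` gives 0.62, and compound 3 `CN1CCN(c2nc3cc(N)ccc3o2)CC1` gives 0.76. Compound 2 thus holds the second highest of the three numbers: its value and that of compound 1 lie within the scatter of each other, while compound 3 sits beyond the scatter above it. For the measured compounds named here, the one measured step is a number 0.24 higher from compound 1 to compound 3 (beyond the scatter).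

Compound 4 `COc1cc(C)cc2nc(N3CCN(C)CC3)oc12` differs from compound 2 in a single place: methoxy in place of methyl on an aromatic carbon. Going by the values given here, no measured step exchanges a methyl for a methoxy, so the step from compound 1 to compound 3 bears on it only loosely, as an indication that replacing one group by another on the core can move this assay by a modest amount. Without a closer precedent, the expected step is a number 0.030 higher from compound 2 to compound 4 (within the scatter), in effect none beyond the scatter. Compound 4 is estimated at 0.65, within a range from 0.5 to 0.8.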

Compound 4, intrinsic activity: the largest response reached, as a fraction of the reference agonist's: 0.56
The estimate for compound 4 lay 0.090 above the measured number, within the range that was stated.
By their numbers in this assay, from the lowest: compounds 1, 4 and 2 (each within the scatter of the next); then compound 3.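

On this aromatic carbon, ortho to a fused ring, methoxy in place of methyl gives a number 0.060 lower from compound 2 to compound 4 (within the scatter) in this assay, so this exchange has no effect on the maximal response that can be told apart from repeat scatter. Methoxy adds an oxygen and a hydrogen-bond acceptor that methyl does not have, and at this position these additions come with no clear difference in the read-out. No independent measurement is available to explain this result.

The compounds shown span only two small groups at this position, so it remains open whether a larger change here, such as a carboxylic acid or a longer chain like ethoxy, would move the response beyond the scatter. Also open, as far as these compounds go, is whether the same exchange would behave alike on a core without the remaining methyl group.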